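Replacing the carbamoyl ether with a nitrile on the shared core

The compounds below may be only part of what the source reports. "The series", "measured", "known", "first", "only" and "open" are said of these compounds alone.

Compound 1 `CC(C)CCn1nc(-c2cccs2)c(O)c(C2=NS(=O)(=O)c3cc(OC(C)C(N)=O)ccc3N2)c1=O` gives 0.217 h in an in vitro ADME assay on microsomes from liver (Homo sapiens) for metabolic stability, tested at 5 uM (on this read-out higher numbers stand for a longer-lived compound and lower numbers for a shorter-lived compound), the lowest of the two plain numbers in this set. Compound 2 `CCC(Oc1ccc2c(c1)S(=O)(=O)N=C(c1c(O)c(-c3cccs3)nn(CCC(C)C)c1=O)N2)C(N)=O` gives 0.35 h in this assay, and the step of a 1.6-fold higher number from compound 1 to compound 2 (0.21 log units; within the scatter) is within the scatter. For compound 3 `CC(C)CCn1nc(-c2cccs2)c(O)c(C2=NS(=O)(=O)c3cc(OCC(=O)NO)ccc3N2)c1=O` the result in this assay is a limit of the assay, > 1 h. The steps of an at least 4.6-fold higher number from compound 1 to compound 3 (0.66 log units; beyond the scatter) and an at least 2.8-fold higher number from compound 2 to compound 3 (0.45 log units; beyond the scatter) are the only ones beyond the scatter, and both change the group on the aromatic oxygen.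

Compound 4 `CC(C)CCn1nc(-c2cccs2)c(O)c(C2=NS(=O)(=O)c3cc(C#N)ccc3N2)c1=O` differs from compound 1 by cyano in place of 1-carbamoylethoxy on an aromatic carbon. For the measured compounds named here, no measured step replaces the side chain with a cyano group, so the measured steps bear on it only indirectly: they show that changing the group on the aromatic oxygen can move the number in this assay, as in compound 3, while the small step of compound 2 did not. The expected step of a 1.8-fold higher number from compound 1 to compound 4 (0.27 log units; within the scatter) is therefore a modest rise with wide uncertainty. Compound 4 is estimated at 0.4 h in this assay, between 0.15 h and 1 h.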

Compound 4, half-life: 0.16 h
Beside the measured number, compound 4's estimate is 2.5-fold (0.40 log units) above it; low and high end bracket the measured number.
By their numbers in this assay, from the lowest: compounds 4, 1 and 2 (each within the scatter of the next, the first and the last beyond it). At a limit, above all of these: compound 3.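

At this aromatic carbon, cyano does no better than the carbamoyl ethers in this assay: the change shows a 1.4-fold lower number from compound 1 to compound 4 (0.13 log units; within the scatter), and against the longer side chain it gives a 2.2-fold lower number from compound 2 to compound 4 (0.34 log units; beyond the scatter). Shortening the substituent to cyano therefore brings no rise over either ether, so among the groups shown only the (hydroxycarbamoyl)methoxy group of compound 3 stands clearly apart. Compound 3 carries a limit of the assay rather than a number, so an at least 6.2-fold lower number from compound 3 to compound 4 (0.79 log units; beyond the scatter) gives only a bound on the size of that gap: the limit of > 1 h in this assay, at which 1 of the 4 values shown sits.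

Going by these compounds, how far compound 3 really lies above compound 4 stays open. So does whether a carboxylic acid, an amine or a plain methoxy group on this aromatic carbon would fall with the carbamoyl ethers and cyano or with compound 3.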